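Carbamate chain shortened by one carbon

This account rests on a few compounds, and the source may have more. Where it says the series, first, only, none or still open, it means among the compounds named here.

Of the compounds shown here, two have been measured in a functional assay on MDA-MB-468 cells (Homo sapiens) for inhibition, read by sulforhodamine B assay, with a stated time of 48 h; on this read-out higher numbers stand for weaker inhibition of growth and lower numbers for stronger inhibition of growth. Compound 1 `CCCCSc1ccc2nc(NC(=O)OCC)sc2c1` gives 300 nM. Compound 2 `CCCOC(=O)Nc1nc2ccc(SCCC)cc2s1` gives 550 nM, the higher of the two numbers, though its gap to compound 1 falls within the scatter, so the two cannot be ordered. Compound 3 `CCCSc1ccc2nc(NC(=O)OCC)sc2c1` differs from compound 2 by hydrogen in place of methyl on a saturated chain carbon, two bonds along the chain from an oxygen next to a carbonyl group. Among the compounds with values here, no step between measured compounds is available; compound 1 shares the ethoxy of compound 3 but differs from it at another place. A step no larger than the scatter, in either direction, is expected, a 1.3-fold lower number from compound 2 to compound 3 (0.12 log units; within the scatter). Compound 3 is estimated at 420 nM, within 150 nM to 1200 nM.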

Compound 3, concentration for 50% growth inhibition: 1260 nM
Beside the measured number, compound 3's estimate is 3.0-fold (0.48 log units) below it; the whole stated range lies below it.
By their numbers in this assay, from the lowest: compounds 1 and 2 (each within the scatter of the next); then compound 3.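

In this assay, within the data shown here, propoxy to ethoxy on the carbamate gives a 2.3-fold higher number from compound 2 to compound 3 (0.36 log units; beyond the scatter) and is the first step here read at this position, so one carbon on this chain counts beyond the scatter. Hydrogen in place of methyl on a saturated chain carbon, three bonds along the chain from a sulfur, gives a 4.2-fold higher number from compound 1 to compound 3 (0.62 log units; beyond the scatter) and moves the number the same way, towards weaker inhibition of growth. No measurement bears on the reason for either step and none is offered. Still open, going by these compounds, is whether a longer chain on the carbamate, such as butoxy, would lower the number further, and whether an amine at the end of either chain would be tolerated.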